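A few compounds are considered here, and "the series" means these few. Any claim that something is new, unique, unknown or untested is made for them only; others in the source may bear on it.

Measured so far:
Compound 1 `CC(C)(C)c1cc(NC(=O)Nc2ccc(Cl)cc2)n(-c2ccc(C(F)(F)F)cc2)n1`: in an assay on isolated protein for inhibition of serine/threonine-protein kinase 10 (Homo sapiens), read by thermal shift assay, tested at 10 uM (on this read-out higher numbers stand for stronger stabilisation of the target against heat and lower numbers for weaker stabilisation of the target), compound 1 gives -0.6 degrees C.
Compound 2 `CC(C)(C)c1cc(NC(=O)Nc2ccc(Cl)cc2)n(-c2ccc(NC(=O)C3CC3)cc2)n1`: in this assay compound 2 gives 3.4 degrees C.

For the measured compounds named here, of these two numbers, compound 2 stands at the top: the only step known, a number 4.0 degrees C higher from compound 1 to compound 2 (beyond the scatter), separates it from compound 1 and lies beyond the scatter. Compound 3 `CC(C)C(=O)Nc1ccc(-n2nc(C(C)(C)C)cc2NC(=O)Nc2ccc(Cl)cc2)cc1` is not yet measured. It differs from compound 2 in one place: isopropyl in place of cyclopropyl on a carbonyl carbon. Going by the values given here, no measured step bears directly on this change. Among the compounds with values here, the single known step, a number 4.0 degrees C higher from compound 1 to compound 2 (beyond the scatter), concerns a different part of the molecule, where a whole group was exchanged on an aromatic carbon, and the cyclopropylcarbonyl unit that arrived in that step is exactly what is now altered. Within the data shown here, because a number 4.0 degrees C higher from compound 1 to compound 2 (beyond the scatter) is the only guide and does not test the swap of cyclopropyl for isopropyl, the expectation rests on the change being a like-for-like exchange, and the estimated change in this assay is small, a number 0.40 degrees C lower from compound 2 to compound 3 (within the scatter), within the scatter. Compound 3 is therefore expected to give 3 degrees C, with a range from 1.5 degrees C to 4.5 degrees C.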

Compound 3, shift of the target's melting temperature: 5.1 degrees C
Estimate against measurement, compound 3: 2.1 degrees C below; measured number above the stated range.
By their numbers in this assay, from the lowest: compound 1; then compound 2; then compound 3.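

In this assay, the group on the carbonyl carbon turns out to matter: a number 1.7 degrees C higher from compound 2 to compound 3 (beyond the scatter), although cyclopropyl and isopropyl each have 3 heavy atoms, all carbon, and the visible difference is that one has a ring and the other does not. This also refines the picture from the first step, since the size of the gain over trifluoromethyl depends on what the amide carries: a number 4.0 degrees C higher from compound 1 to compound 2 (beyond the scatter) with (cyclopropylcarbonyl)amino, whereas with (isopropylcarbonyl)amino there is a number 5.7 degrees C higher from compound 1 to compound 3 (beyond the scatter). Nothing available explains why the open, branched group gives the higher number, so the result stands as an observation only.

For the compounds shown here, with only two groups compared on this carbonyl carbon, it remains open whether a cyclobutyl ring or a straight propyl chain there would give a higher or a lower number than isopropyl. The compounds shown also leave open how a simple amine or a carboxylic acid would compare with the amide on the aromatic carbon where trifluoromethyl once stood.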